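This account rests on a few compounds, and the source may have more. Where it says the series, first, only, none or still open, it means among the compounds named here.

Working notes on the series, read in a functional assay on KB cells (Homo sapiens) for inhibition (a lower number here means a stronger inhibitor, a higher number a weaker inhibitor), throughout. Compound 1 (`CCOCn1c(N)c(C(N)=O)c2c(N)ncnc21`) stands at > 100000 nM, which is a limit of the assay. For the measured compounds named here, compound 2 (`CCOCn1c(N)c(C#N)c2c(N)ncnc21`) gives 138000 nM, the only actual number so far. Going by the values given here, the one measured step, a step that the limit leaves unreadable from compound 1 to compound 2, involves cyano in place of carbamoyl on an aromatic carbon and gives no usable size. Among the compounds with values here, the only further evidence is the limit of > 100000 nM in this assay, at which 1 of the 2 values shown sits, so no measured step sizes the next change. Compound 3 (`CCOCn1cc(C#N)c2c(N)ncnc21`) follows from compound 2 by hydrogen in place of amino on an aromatic carbon. Without a measured guide, no shift beyond the scatter is expected, and a 1.2-fold lower number from compound 2 to compound 3 (0.06 log units; within the scatter) is an estimate only. Compound 3 is expected near 120000 nM, with an estimated range from 40000 nM to 400000 nM in this assay for now.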

Compound 3, half-maximal inhibitory concentration: > 100000 nM
Compound 3: no number, only a limit (the forecaster's own chance of this, stated with the estimate: 45%); the middle value is on the limit's open side.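

For the compounds shown here, compound 3 gives > 100000 nM, a limit of the assay, so no step from compound 2 to compound 3 can be read. The compounds shown leave open how far hydrogen in place of amino moves the value.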